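A few compounds are considered here, and "the series" means these few. Any claim that something is new, unique, unknown or untested is made for them only; others in the source may bear on it.

Compound 1 `OC(CCn1nc2c(Br)c(Br)c(Br)c(Br)c2n1)c1cccc(Cl)c1` gives 96% in a functional assay on MCF7 cells (Homo sapiens) for antiproliferative activity, read by MTT assay, with a stated time of 24 h, tested at 25 uM; a lower number here means a stronger effect, a higher number a weaker effect of the compound at the concentration tested.
Compound 2 `OC(CCn1nc2c(Br)c(Br)c(Br)c(Br)c2n1)c1ccc(Br)cc1` gives 59% in this assay.

Compound 2 stands lowest of the two numbers in this assay. Its nearest neighbour is compound 1, which sits higher. Within the data shown here, the single measured step, a number 37 percentage points lower from compound 1 to compound 2 (beyond the scatter), is large and beyond the scatter; it replaces 3-chlorophenyl with 4-bromophenyl, so it changes the halogen and the substitution pattern of the phenyl at once.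

Compound 3 `OC(CCn1nc2c(Br)c(Br)c(Br)c(Br)c2n1)c1ccc(Cl)cc1` has not yet been measured. It differs from compound 2 in one place: chloro in place of bromo on an aromatic carbon. Among the measured compounds shown here, no measured pair shows bromo against chloro on the same aromatic carbon, and the one step available mixes that exchange with a different phenyl pattern, so it bears on the present step only loosely and gives no clean direction. The expected step of a number 9 percentage points higher from compound 2 to compound 3 (within the scatter) is therefore small, most likely within the scatter, with a slight lean toward a higher number. On that basis compound 3 is estimated at 68% in this assay, with a range from 45% to 95%.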

Compound 3, a percentage reported as activity, at one concentration (the size of the read-out at that concentration, not a potency): 96%
Beside the measured number, compound 3's estimate is 28 percentage points below it, and the stated range ends below it.
By their numbers in this assay, from the lowest: compound 2; then compounds 1 and 3 (each within the scatter of the next).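

The exchange of bromo for chloro on this aromatic carbon, para to a large group, can now be read on its own, with a number 37 percentage points higher from compound 2 to compound 3 (beyond the scatter) in this assay for this single change. Moving the chlorine, 4-chlorophenyl in place of 3-chlorophenyl, gives no change at the digits printed from compound 1 to compound 3 (within the scatter) in the same test, so among these compounds the position of the chlorine makes no visible difference, and the large gap seen earlier goes with the bromo of compound 2 rather than with the substitution pattern. Nothing available explains why bromo and chloro part so sharply at this place.

The compounds shown do not tell whether a fluoro, a methoxy or an amine on this carbon would side with bromo or with chloro. They also leave open whether 3-bromophenyl would follow 4-bromophenyl, which would show if the effect of bromo depends on where it sits, and a reading at one concentration gives the size of the effect there, not a potency.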